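Aryl ether variation in a carbamate series: working notes

The compounds below may be only part of what the source reports. "The series", "measured", "known", "first", "only" and "open" are said of these compounds alone.

Measured so far:
- compound 1 `CCC(COc1cccc(Br)c1)OC(=O)NCc1ccccc1`; in an assay for inhibition of zeta-carotene desaturase, chloroplastic/chromoplastic (Capsicum annuum), using a Dixon plot, with a stated time of 8 h (a higher number here means a weaker inhibitor, a lower number a stronger inhibitor), compound 1 gives > 100000 nM, which is a limit of the assay.
- compound 2 `CCOC(=O)c1cccc(OCC(CC)OC(=O)NCc2ccccc2)c1`; in this assay compound 2 gives > 100000 nM, also a limit.
- compound 3 `CCC(COc1cccc(NC(C)=O)c1)OC(=O)NCc1ccccc1`; in this assay compound 3 gives > 100000 nM, again a limit.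

Compound 1 therefore stands at the limit, as do the other two, all three sitting at the limit of > 100000 nM in this assay, at which 3 of the 3 values shown sit. The steps a step that the two limits leave unreadable from compound 1 to compound 2, a step that the two limits leave unreadable from compound 1 to compound 3 and a step that the two limits leave unreadable from compound 2 to compound 3 are accordingly not readable in size or direction.

Compound 4 `CCC(COc1c(Cl)cccc1Cl)OC(=O)NCc1ccccc1` differs from compound 1 in 2,6-dichlorophenyl in place of 3-bromophenyl on an oxygen on a saturated carbon. The measured steps all vary the same aryl ether and bear on this change, yet none gives a readable size, so no direction beyond the scatter can be expected from them. Compound 4 is expected at 100000 nM, within 30000 nM to 300000 nM, most likely reported as a limit. The expected step of a number no higher from compound 1 to compound 4 (the limit leaves the size open) is thus essentially none.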

Compound 4, half-maximal inhibitory concentration: > 100000 nM
Compound 4: no number, only a limit; the forecaster's own chance of this, stated with the estimate: 85%; the middle value sits exactly at the limit.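

Compound 4 gives > 100000 nM in this assay, which is a limit, so its step from compound 1 cannot be read: the limit of > 100000 nM in this assay, at which 4 of the 4 values shown sit. The compounds shown leave open whether any aryl ether on the shared core gives a measurable value.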